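Dichlorophenyl Thioether to Fluorophenyl Ether on a Shared Core

A few compounds are considered here, and "the series" means these few. Any claim that something is new, unique, unknown or untested is made for them only; others in the source may bear on it.

Compound 1, `COc1ccc(Sc2nc3cc(N)cc(N)c3nc2-c2ccccc2)cc1`: in a functional assay on IGROV-1 cells (Homo sapiens) for inhibition, read by sulforhodamine B assay, with a stated time of 48 h (a lower number here means that less compound is tolerated, a higher number that more compound is tolerated), compound 1 gives < 100000 nM, a limit of the assay and not a number.
Compound 2, `Nc1cc(N)c2nc(-c3ccccc3)c(Sc3ccc(Cl)c(Cl)c3)nc2c1`: in this assay compound 2 gives < 100000 nM, likewise a limit and not a number.

Among the compounds with values here, compound 2 therefore stands only at a limit, and the one further value shown is a limit too. Within the data shown here, the single measured step, a step that the two limits leave unreadable from compound 1 to compound 2, has no readable size, as both of its compounds sit at the limit of < 100000 nM in this assay, at which 2 of the 2 values shown sit. Compound 3, `Nc1cc(N)c2nc(-c3ccccc3)c(Oc3ccc(F)cc3)nc2c1`, differs from compound 2 by 4-fluorophenoxy in place of (3,4-dichlorophenyl)sulfanyl on an aromatic carbon. Among the measured compounds shown here, no measured step bears on this change with a readable size, so nothing supports an expected shift in this assay in either direction beyond the scatter. Compound 3 is estimated at 20000 nM, with a range from 3000 nM to 95000 nM. The step this estimate implies, a step that the limit leaves unreadable from compound 2 to compound 3, is expected to be small and uncertain, and a further limit rather than a number is quite possible.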

Compound 3, concentration lethal to 50% of the cells: < 100000 nM
Compound 3 gave a limit, no number; the forecaster's own chance of this, stated with the estimate: 50%; the middle value does not contradict the limit.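

Compound 3 also gives a limit and not a number, so neither of its steps, from compound 2 or from compound 1, can be read: the limit of < 100000 nM in this assay, at which 3 of the 3 values shown sit.

The compounds shown leave open whether 4-fluorophenoxy, (3,4-dichlorophenyl)sulfanyl or (4-methoxyphenyl)sulfanyl on the shared core changes the result in this assay at all.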